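This account rests on a few compounds, and the source may have more. Where it says the series, first, only, none or still open, it means among the compounds named here.

In an ADME assay on the whole organism (strain CD-1) for pharmacokinetics, with Mus musculus as the target, at a dose of 3 mg/kg by the intravenous route (on this read-out lower numbers stand for slow clearance and higher numbers for fast clearance), three compounds have been measured so far. Compound 1 `CN(Cc1ccccc1OCCCCCC(=O)O)C(=O)c1ccc(-c2ccco2)cc1` gives 44 mL/min/kg, compound 2 `CC(CCCCOc1ccccc1CN(C)C(=O)c1ccc(-c2ccco2)cc1)C(=O)O` gives 3 mL/min/kg, and compound 3 `C[C@H](CCCOc1ccccc1CN(C)C(=O)c1ccc(-c2ccco2)cc1)CC(=O)O` gives 0.3 mL/min/kg, the lowest of the three numbers. Compound 4 `C[C@@H](CCCOc1ccccc1CN(C)C(=O)c1ccc(-c2ccco2)cc1)CC(=O)O` is the next to be examined. It differs from compound 3 by the two compounds have the same atoms and bonds and differ only in configuration as drawn: 1 of 1 stereo elements differ; a stereocentre at a saturated chain carbon is drawn R in compound 3 and S in compound 4: the two have the same atoms and bonds, and a stereocentre at a saturated chain carbon is drawn R in compound 3 and S in compound 4.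

For the measured compounds named here, no measured step inverts a stereocentre, so the size of this change cannot be read directly from the data. The closest evidence comes from the methyl-bearing chains. The change is large in a 15-fold lower number from compound 1 to compound 2 (1.17 log units; beyond the scatter) and larger still in a 150-fold lower number from compound 1 to compound 3 (2.17 log units; beyond the scatter), while the modest 10-fold lower number from compound 2 to compound 3 (1.00 log units; beyond the scatter) shows that the methyl's place on the chain also matters. All three steps lie beyond the scatter. Across these compounds, then, the number responds strongly to the detail of the chain, and compound 3 sits at the low extreme. A move upward is therefore expected, though probably not all the way to the value of compound 1. The expected change is a 10-fold higher number from compound 3 to compound 4 (1.00 log units; beyond the scatter), an estimate that carries wide uncertainty. For compound 4 the estimated value is 3 mL/min/kg, with an expected range of 0.5 mL/min/kg to 20 mL/min/kg.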

Compound 4, clearance: 1.3 mL/min/kg
Estimate against measurement, compound 4: 2.3-fold (0.36 log units) above, and the stated range covers the measured number.
By their numbers in this assay, from the lowest: compound 3; then compound 4; then compound 2; then compound 1.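

In this assay, inverting the stereocentre at this saturated chain carbon brings a 4.3-fold higher number from compound 3 to compound 4 (0.64 log units; beyond the scatter), and the whole of that step can be traced to a single difference: the fact that compounds 3 and 4 differ only in the configuration as drawn

The direction of the methyl effect at this position does not depend on the configuration, since methyl in place of hydrogen lowers the number with either drawing, as a 150-fold lower number from compound 1 to compound 3 (2.17 log units; beyond the scatter) and a 34-fold lower number from compound 1 to compound 4 (1.53 log units; beyond the scatter) show, but the size of the fall does. The same holds for the move of the methyl along the chain, where a 2.3-fold lower number from compound 2 to compound 4 (0.36 log units; beyond the scatter) points the same way as a 10-fold lower number from compound 2 to compound 3 (1.00 log units; beyond the scatter) and is the smaller of the two.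

Compound 2 is drawn with no configuration at its methyl-bearing carbon, so the compounds shown leave open whether its two mirror forms would also separate in this read-out. They also leave open how the number would respond to an ethyl group or a second methyl on the carbon of compounds 3 and 4, and whether either configuration would keep its place in the order with such a group.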